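Reversing a para substituent to an ortho bromine

The source may hold more compounds than are shown below. What is called first, only, known or untested is meant among the compounds shown, and "the series" means these compounds.

Measured so far:
compound 1, `O=C(Nc1ccccc1[N+](=O)[O-])N[C@H]1CC[C@H](Oc2ccc(F)cc2)CC1`: 3500 nM
compound 2, `CSc1ccc(NC(=O)N[C@H]2CC[C@H](Oc3ccc(F)cc3)CC2)cc1`: > 20000 nM

In a functional assay on CRL2813 cells (Homo sapiens) for cytotoxicity, read by sulforhodamine B assay, with a stated time of 5 days (a lower number here means a stronger inhibitor, a higher number a weaker inhibitor), compound 1 gives 3500 nM. For compound 2 this assay reports only a limit, > 20000 nM. Accordingly compound 2 stands at the limit of > 20000 nM in this assay, at which 1 of the 2 values shown sits, and its place on the numbers is known only as a bound, not as a value. Among the measured compounds shown here, the one measured step, an at least 5.7-fold higher number from compound 1 to compound 2 (0.75 log units; beyond the scatter), shows that 4-(methylsulfanyl)phenyl on the amide-type nitrogen gave a weaker result than 2-nitrophenyl.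

Compound 3, `O=C(Nc1ccccc1Br)N[C@H]1CC[C@H](Oc2ccc(F)cc2)CC1`, carries the change (2-bromophenyl in place of 4-(methylsulfanyl)phenyl on an amide-type nitrogen). This step undoes the 4-(methylsulfanyl)phenyl that went with the weakening from compound 1 to compound 2, and puts a 2-substituted phenyl back in its place, as in compound 1. The step is therefore expected to lower the number in this assay, by about an at least 4.0-fold lower number from compound 2 to compound 3 (0.60 log units; beyond the scatter), though from a limit the true size cannot be read exactly. Compound 3 is expected to give 5000 nM. The lower end expected for compound 3 is 1500 nM. The upper end expected for compound 3 is 20000 nM.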

Compound 3, half-maximal inhibitory concentration: 7700 nM
Compound 3: the middle estimate sits 1.5-fold (0.19 log units) below what was measured, and the stated range covers the measured number.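

In this assay, a second 2-substituted phenyl also gives a lower number than the 4-(methylsulfanyl)phenyl: putting 2-bromophenyl on the amide-type nitrogen gives an at least 2.5-fold lower number from compound 2 to compound 3 (0.41 log units; beyond the scatter). So the lower numbers seen among these compounds are not tied to 2-nitrophenyl alone, although the two 2-substituted groups do not match: bromo in place of nitro on an aromatic carbon gives a 2.2-fold higher number from compound 1 to compound 3 (0.34 log units; beyond the scatter), which leaves compound 1 with the lower number of the pair. The recovery from compound 2 can be read only as a bound, because compound 2 carries a limit and not a measured number: the limit of > 20000 nM in this assay, at which 1 of the 3 values shown sits.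

The change from compound 2 to compound 3 alters both the substituent and its place on the phenyl, so the compounds shown cannot separate the contribution of one from that of the other. Also open, going by these compounds, is how the number in this assay would respond to an amine or a carboxylic acid on this phenyl, since bromo and nitro are the only two substituents compared directly here.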